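The source may hold more compounds than are shown below. What is called first, only, known or untested is meant among the compounds shown, and "the series" means these compounds.

Compound 1 `CCOC(=O)C(=O)CC(=O)/C=C/c1cn(-c2ccc(O)cc2)c2ccccc12` and compound 2 `CCOC(=O)C(=O)CC(=O)/C=C/c1cn(Cc2ccc(F)cc2)c2ccccc12` share the core and differ only on the aromatic nitrogen. In an assay on isolated protein for inhibition of DNA nucleotidylexotransferase (Homo sapiens), read by scintillation counting, with a stated time of 10 min (on this read-out lower numbers stand for stronger inhibition and higher numbers for weaker inhibition), compound 1 reaches only the limit of the assay, > 40 uM. In this assay compound 2 likewise stops at the limit, > 40 uM. The step that the two limits leave unreadable from compound 1 to compound 2 stays unreadable because the limit of > 40 uM in this assay, at which 2 of the 2 values shown sit, holds both values. Compound 2 thus stands at the limit, with no number behind it. Compound 3 `CCOC(=O)C(=O)CC(=O)/C=C/c1cn(CC(=O)N2CCOCC2)c2ccccc12` carries (morpholin-4-yl)carbonyl in place of 4-fluorophenyl on a saturated chain carbon bound to an aromatic nitrogen. For the measured compounds named here, the single measured step gives no size to draw on, so no readable step beyond the scatter is expected from compound 2 to compound 3. The step that the limit leaves unreadable from compound 2 to compound 3 is expected to stay within scatter, most likely at the limit again. Compound 3 is estimated at 60 uM, within 20 uM to 200 uM.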

Compound 3, concentration for 50% inhibition: > 40 uM
Compound 3 was reported as a limit; the forecaster's own chance of this, stated with the estimate: 75%; the middle value lies beyond the limit too.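

For the compounds shown here, no step among compound 1, compound 2 and compound 3 can be read, because all three stop at one assay limit: the limit of > 40 uM in this assay, at which 3 of the 3 values shown sit. The compounds shown leave open how strongly each inhibits in this assay, and whether the groups on the aromatic nitrogen differ at all.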